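This account rests on a few compounds, and the source may have more. Where it says the series, first, only, none or still open, it means among the compounds named here.

In a functional assay on A549 cells (Homo sapiens) for antiproliferative activity, read by WST assay, with a stated time of 72 h (a lower number here means that less compound is needed, a higher number that more compound is needed for the effect), compound 1 (`CCCCCCNCC(=O)Nc1ccc(/C(N)=N/O)cc1`) gives 658000 nM as a measured number. Compound 2 (`CCCCCCNCCCC(=O)Nc1ccc(/C(N)=N/O)cc1`) shows > 1000000 nM as its reading, and this is a limit of the assay, not a number. Compound 3 (`CCCCCCNC(=O)Nc1ccc(/C(N)=N/O)cc1`) shows > 1000000 nM as its reading, again a limit. Compound 2 therefore stands on the limit of > 1000000 nM in this assay, at which 2 of the 3 values shown sit, and has no exact place on the scale.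

The next compound to be tested is compound 4 (`CCCCNCCCC(=O)Nc1ccc(/C(N)=N/O)cc1`). It keeps the shared core of compound 2 and changes only the far end of the chain on the amine: hydrogen in place of ethyl on a saturated chain carbon, four bonds along the chain from an amine nitrogen describes the difference, hydrogen in place of ethyl on a saturated chain carbon, four bonds along the chain from an amine nitrogen. Seen another way, a butyl stretch becomes an ethyl one.

Among the compounds with values here, no measured pair shows what such a trim does on its own. Compound 2 offers only > 1000000 nM as a limit to start from. The expectation is therefore no step beyond the usual scatter in this assay and no favoured direction, and the expected change a number no higher from compound 2 to compound 4 (the limit leaves the size open) reflects that. For compound 4 the estimated value is 1000000 nM with an expected range from 500000 nM to 2500000 nM and, as an expectation, a good chance of only a limit.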

Compound 4, half-maximal effective concentration: > 1000000 nM
Compound 4 was reported as a limit (the forecaster's own chance of this, stated with the estimate: 85%); the middle value lies on the limit itself.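

Shortening the butyl stretch of compound 2 to an ethyl one does not bring compound 4 off the ceiling in this assay, and its reading remains a limit of the assay, not a number: the limit of > 1000000 nM in this assay, at which 3 of the 4 values shown sit.

With a limit on both sides, the step between compound 2 and compound 4 cannot be read, so neither its size nor its direction is known. Set against compound 1, the only compound here with a measured number, the result reads as an at least 1.5-fold higher number from compound 1 to compound 4 (0.18 log units; that floor lies within the scatter), so this comparison establishes no difference beyond the usual scatter.

The compounds shown leave open whether a longer chain on the amine, such as octyl, or a carboxylic acid at the far end of the chain would bring a reading into the measurable range. They also leave open whether the hexyl chain or the shorter link to the amide in compound 1 is what goes with its measured number, as these two features are not separated here.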